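The source may hold more compounds than are shown below. What is called first, only, known or untested is meant among the compounds shown, and "the series" means these compounds.

Series notes. Compound 1 `Cc1cccc(Oc2ccc(N3CCC[C@H]3CC(=O)O)cc2)c1` and compound 2 `O=C(O)C[C@@H]1CCCN1c1ccc(Oc2cccc(Cl)c2)cc1` share a core and differ by chloro in place of methyl on an aromatic carbon; in a functional assay on cells for agonist activity at Free fatty acid receptor 1 (Homo sapiens), read by FLIPR and calcium flux, with a stated time of 100 s (a higher number here means that more compound is needed for the effect, a lower number that less compound is needed), compound 1 gives 260 nM and compound 2 gives 680 nM, so that a 2.6-fold higher number from compound 1 to compound 2 (0.42 log units; beyond the scatter). Compound 3 `Cc1cccc(Oc2ccc(N3C[C@@H](C(F)(F)F)C[C@H]3CC(=O)O)cc2)c1C` gives 110 nM in this assay; how its core differs from that of compound 1 is not broken down here. Compound 4 `Cc1c(Cl)cccc1Oc1ccc(N2C[C@@H](C(F)(F)F)C[C@H]2CC(=O)O)cc1` is not yet measured. It differs from compound 3 by chloro in place of methyl on an aromatic carbon, the same kind of change as seen from compound 1 to compound 2, though here the place is also ortho to a methyl group, which is absent in the earlier pair. Because a 2.6-fold higher number from compound 1 to compound 2 (0.42 log units; beyond the scatter), a step of similar size is expected, a 2.5-fold higher number from compound 3 to compound 4 (0.39 log units; beyond the scatter), while keeping in mind that the surroundings of the place differ. Compound 4 is therefore estimated at 270 nM, with a range of 110 nM to 650 nM.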

Compound 4, half-maximal effective concentration: 82 nM
Compound 4: middle estimate off by 3.3-fold (0.52 log units), on the high side; measured number outside the range, below it.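

In this assay, chloro in place of methyl on an aromatic carbon does not carry over as a fixed step between these two cores: the same change on two cores in this assay, a 2.6-fold higher number (0.42 log units; beyond the scatter) from compound 1 to compound 2 and a 1.3-fold lower number (0.13 log units; within the scatter) from compound 3 to compound 4, 3.5-fold (0.55 log units) apart, beyond the scatter of two such steps. The new step reads a 1.3-fold lower number from compound 3 to compound 4 (0.13 log units; within the scatter), so on this core the exchange leaves no difference that can be told from the scatter. With one pair per core, this does not show whether the trifluoromethyl group, the methyl group ortho to the place, or both account for the gap, nor how the change behaves on any further core.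

Left open is which of these two features matters for the size of the step. Also open, going by these compounds, is how a methoxy or nitrile group at the same place compares with methyl and chloro.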